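Swapping Phenyl for Naphthylmethyl in a Macrocycle

The source may hold more compounds than are shown below. What is called first, only, known or untested is meant among the compounds shown, and "the series" means these compounds.

The compounds here are macrocycles tested in an assay on isolated protein for displacement of a labelled ligand from Motilin receptor (Homo sapiens); a lower number here means a stronger inhibitor, a higher number a weaker inhibitor. Compound 1 `CCC[C@@H]1NC(=O)[C@@H](C(C)C)NC(=O)[C@@H](Cc2ccc(O)cc2)NCCCc2ccccc2CCNC1=O` shows only a limit of the assay, > 10000 nM. Compound 2 `CCC[C@@H]1NC(=O)[C@@H](C(C)C)NC(=O)[C@@H](Cc2ccc(O)cc2)NCCCCc2ccccc2CCNC1=O` gives 6060 nM. Compound 3 `CCC[C@@H]1NC(=O)[C@@H](C(C)C)NC(=O)[C@@H](c2ccccc2)NCCOc2ccccc2CCCNC1=O` likewise reaches only a limit, > 10000 nM. Compound 3 thus sits at the limit of > 10000 nM in this assay, at which 2 of the 3 values shown sit, so it cannot be ranked against the others beyond that. Compound 4 `CCC[C@@H]1NC(=O)[C@@H](C(C)C)NC(=O)[C@@H](Cc2cccc3ccccc23)NCCOc2ccccc2CCCNC1=O` differs from compound 3 in one place: (naphthalen-1-yl)methyl in place of phenyl on a saturated ring carbon. Among the measured compounds shown here, no measured pair shows what this exchange does, so the outlook is uncertain. Compound 4 is expected to reach a measurable value, 4000 nM, within a range of 800 nM to 20000 nM. The step expected from the limit is an at least 2.5-fold lower number from compound 3 to compound 4 (0.39 log units; beyond the scatter), with a real chance that compound 4 also yields only a limit.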

Compound 4, inhibition constant: 8.3 nM
Compound 4: the middle estimate sits 480-fold (2.68 log units) above what was measured; measured number outside the range, below it.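

Putting (naphthalen-1-yl)methyl in place of phenyl on this saturated ring carbon brings an at least 1200-fold lower number from compound 3 to compound 4 (3.08 log units; beyond the scatter) in this assay. That step is only a minimum, since compound 3 gives a limit and not a number: the limit of > 10000 nM in this assay, at which 2 of the 4 values shown sit.

Together, these results show that the group at this one ring carbon can separate a compound with no measurable value from a strong binder, which compound 1, compound 2 and compound 3 could not show. The compounds shown leave open whether the gain comes from the second aromatic ring or from the added methylene link. A benzyl group or a (naphthalen-2-yl)methyl group at this carbon would help to tell these apart.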